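From compound 2 to compound 3: amino for 4-fluorophenyl

The source may hold more compounds than are shown below. What is called first, only, known or untested is meant among the compounds shown, and "the series" means these compounds.

Of the compounds shown here, two sharing one core have been measured so far. In a functional assay on V79-379A cells (Cricetulus griseus) for cytotoxicity, read by MTT assay, in the presence of a further agent that is not named here (on this read-out lower numbers stand for stronger inhibition and higher numbers for weaker inhibition), compound 1 (`COC1=CC(=O)c2c(c(CCl)cn2C)C1=O`) gives 304000 nM, while compound 2 (`COC1=CC(=O)c2c(c(COC(=O)c3ccc(F)cc3)cn2C)C1=O`) gives 700 nM. Compound 2 therefore holds the lower of the two numbers, and the gap between them lies well beyond the scatter.

Compound 3 (`COC1=CC(=O)c2c(c(COC(N)=O)cn2C)C1=O`) has amino in place of 4-fluorophenyl on a carbonyl carbon. Going by the values given here, no measured step isolates this change, so the expectation rests on thin evidence. Among the compounds with values here, the group that leaves occurs only in compound 2, which stands at 700 nM, and the only other reference is compound 1 at 304000 nM. A move toward weaker inhibition, beyond the scatter, is expected, with an estimated size of a 5.7-fold higher number from compound 2 to compound 3 (0.76 log units; beyond the scatter). For compound 3 the estimated value is 4000 nM, with an expected range of 500 nM to 30000 nM.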

Compound 3, half-maximal inhibitory concentration: 3000 nM
Estimate against measurement, compound 3: 1.3-fold (0.12 log units) above, within the range that was stated.
By their numbers in this assay, from the lowest: compound 2; then compound 3; then compound 1.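

In this assay the 4-fluorophenyl on the carbonyl carbon is not essential for activity: amino in its place gives a 4.3-fold higher number from compound 2 to compound 3 (0.63 log units; beyond the scatter), a modest step even though the whole aromatic ring leaves. Carbamoyloxy in place of chloro on the saturated chain carbon gives a 100-fold lower number from compound 1 to compound 3 (2.01 log units; beyond the scatter), so compound 3 stands far closer to compound 2 than to compound 1. No measurement at hand accounts for either step.

The compounds shown leave open whether the carbonyl is needed at all, a question that a hydroxyl or an amine on the saturated chain carbon would address. Also open, going by these compounds, is whether methylamino or dimethylamino on the carbonyl carbon would read like amino, or whether a phenyl without the fluorine would read like 4-fluorophenyl.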